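Compound 4 from compound 2: methoxy in place of chloro

This account rests on a few compounds, and the source may have more. Where it says the series, first, only, none or still open, it means among the compounds named here.

Three amides on the shared core have been measured. Compound 1 `O=C(Nc1nc2ccc(Cl)cc2s1)c1cc(-c2ccc(F)cc2)n2nc(-c3ccccc3)cc2n1` gives 19800 nM in a functional assay on MCF7 cells (Homo sapiens) for cytotoxicity, read by MTT assay, with a stated time of 48 h; a higher number here means a weaker inhibitor, a lower number a stronger inhibitor. Compound 2 `COc1ccc(-c2cc(C(=O)Nc3nc4ccc(Cl)cc4s3)nc3cc(-c4ccccc4)nn23)cc1` gives 4890 nM in this assay, and compound 3 `COc1cc(-c2cc(C(=O)Nc3nc4ccc(Cl)cc4s3)nc3cc(-c4ccccc4)nn23)cc(OC)c1OC` gives 30200 nM. Compound 2 carries the lowest number of the three: the step of a 4.0-fold lower number from compound 1 to compound 2 (0.61 log units; beyond the scatter) and the step of a 6.2-fold higher number from compound 2 to compound 3 (0.79 log units; beyond the scatter) both lie beyond the scatter, whereas a 1.5-fold higher number from compound 1 to compound 3 (0.18 log units; within the scatter) does not.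

Compound 4 `COc1ccc(-c2cc(C(=O)Nc3nc4ccc(OC)cc4s3)nc3cc(-c4ccccc4)nn23)cc1` differs from compound 2 in one place: methoxy in place of chloro on an aromatic carbon. Going by the values given here, every measured step so far changes the aryl group on the core, 4-fluorophenyl, 4-methoxyphenyl or 3,4,5-trimethoxyphenyl; none of them touches the chloro that compound 4 replaces. Among the compounds with values here, no measured step therefore bears on this change, and nothing in the numbers points in either direction. The working expectation is that compound 4 stays close to compound 2. The step of a 1.0-fold higher number from compound 2 to compound 4 (0.01 log units; within the scatter) is expected to fall within the scatter, with no direction favoured. Compound 4 is estimated at 5000 nM in this assay. Within the data shown here, the range for compound 4 is expected to run from 1700 nM to 15000 nM; it is kept wide, as no measured pair speaks to a change on the fused ring.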

Compound 4, half-maximal inhibitory concentration: 19100 nM
For compound 4 the middle estimate is 3.8-fold (0.58 log units) below the measured one; the measured number lies above the stated range.
By their numbers in this assay, from the lowest: compound 2; then compounds 4, 1 and 3 (each within the scatter of the next).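

In this assay, going by these compounds alone, the chloro of the 6-chloro-1,3-benzothiazol-2-yl group proves not to be a silent part of compound 2: a 3.9-fold higher number from compound 2 to compound 4 (0.59 log units; beyond the scatter) shows that this carbon of the fused system, untouched by the earlier steps, can also move the number beyond the scatter. Methoxy goes with the lower number on the aryl group in a 4.0-fold lower number from compound 1 to compound 2 (0.61 log units; beyond the scatter) but with the higher number here, so across these two sites the group is not tied to one direction, and compound 2 keeps the lowest number of the four. Nothing at hand gives a reason for this rise.

The compounds shown leave open whether the rise follows the entering methoxy or the departing chloro, and whether it recurs with 4-fluorophenyl or 3,4,5-trimethoxyphenyl on the shared core. Also open, on these data alone, is how an amine, a carboxylic acid, a bromo or a longer ether chain such as ethoxy would read on this carbon of the fused ring.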